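The source may report more compounds than this note shows. Statements on the series, on what has been measured and on what is new or still open speak of the compounds shown alone.

Working notes on the series.

Compound 1 `C=CCOc1c(C)c(C)c2c(c1C)CCC(C)(COc1ccc(/C=C3\SC(=O)NC3=O)cc1)O2` gives 42% in a functional assay on MCF7 cells (Homo sapiens), tested at 5 uM; a lower number here means a stronger effect, a higher number a weaker effect of the compound at the concentration tested. Going by the values given here, compound 2 `C=CCOc1c(C)c(C)c2c(c1C)CCC(C)(COc1ccc(/C=C3\SC(=O)NC3=O)cc1OC)O2` gives 5%, the lowest of the three numbers so far; compound 3 `Cc1c(C)c2c(c(C)c1OC/C=C/c1ccccc1)CCC(C)(COc1ccc(/C=C3\SC(=O)NC3=O)cc1)O2` gives 65%. The two measured steps both start from compound 1: a number 37 percentage points lower from compound 1 to compound 2 (beyond the scatter), and a number 23 percentage points higher from compound 1 to compound 3 (beyond the scatter).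

Compound 4 `COc1cc(/C=C2\SC(=O)NC2=O)ccc1OCC1(C)CCc2c(C)c(OCC=C(C)C)c(C)c(C)c2O1` is not yet measured. It keeps the methoxy of compound 2 and changes the chain: 2-methylprop-1-en-1-yl in place of vinyl on a saturated chain carbon bound to an oxygen on an aromatic ring. Among the compounds with values here, of the measured steps, only the one from compound 1 to compound 3 bears on this change, since it too alters the chain on the saturated carbon bound to the oxygen on the aromatic ring, and it was modest, a number 23 percentage points higher from compound 1 to compound 3 (beyond the scatter); the step from compound 1 to compound 2 concerns a different place and is not informative here. A rise of similar or somewhat smaller size is therefore expected for compound 4, because the step of a number 23 percentage points higher from compound 1 to compound 3 (beyond the scatter) went that way, so that the step of a number 15 percentage points higher from compound 2 to compound 4 (beyond the scatter) is estimated. For compound 4 the expected value in this assay is 20%, within 5% to 45%.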

Compound 4, a percentage reported as activity, at one concentration (the size of the read-out at that concentration, not a potency): 78%
The estimate for compound 4 lay 58 percentage points below the measured number, outside the stated range (above it).
By their numbers in this assay, from the lowest: compound 2; then compound 1; then compound 3; then compound 4.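

The step of a number 73 percentage points higher from compound 2 to compound 4 (beyond the scatter) shows that this place on a saturated chain carbon bound to an oxygen on an aromatic ring responds strongly even to a small change: 2-methylprop-1-en-1-yl for vinyl adds two carbons, with no ring, no hydrogen-bond donor or acceptor and no charge entering. It also shows that the methoxy step a number 37 percentage points lower from compound 1 to compound 2 (beyond the scatter) does not secure a low number on its own, as compound 4 carries the same methoxy and still has the highest number of the four. Nothing available bears on the cause of this sensitivity.

Still open, going by these compounds, is whether 2-methylprop-1-en-1-yl would give a step of this size on the core of compound 1, without the methoxy. Also open, on these data alone, is how a saturated propyl chain, or an amine or a carboxylic acid at the end of the chain, would read in this place.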